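The compounds below may be only part of what the source reports. "The series", "measured", "known", "first", "only" and "open" are said of these compounds alone.

Compound 1 `CCNC(=O)N1CCN(C(=S)SCc2cn(Cc3ccccc3F)nn2)CC1` carries an ethylcarbamoyl group on its piperazine. In a functional assay on SMMC-7721 cells (Homo sapiens) for cytotoxicity, read by MTT assay, with a stated time of 72 h (on this read-out lower numbers stand for stronger inhibition and higher numbers for weaker inhibition), compound 1 gives only a limit, > 128000 nM. Compound 2 `CC(C)NC(=O)N1CCN(C(=S)SCc2cn(Cc3ccccc3F)nn2)CC1` differs by methyl in place of hydrogen on a saturated chain carbon bound to an amide-type nitrogen and a saturated chain carbon, and in this assay compound 2 gives 7130 nM, so the step is an at least 17-fold lower number from compound 1 to compound 2 (1.25 log units; beyond the scatter). Compound 3 `CCNC(=O)N1CCN(C(=S)SCc2cn(Cc3ccc(Cl)cc3)nn2)CC1` differs from compound 1 by 4-chlorophenyl in place of 2-fluorophenyl on a saturated chain carbon bound to an aromatic nitrogen; the step is a step that the two limits leave unreadable from compound 1 to compound 3. In this assay compound 3 gives only a limit, > 128000 nM. Compound 4 `CC(C)NC(=O)N1CCN(C(=S)SCc2cn(Cc3ccc(Cl)cc3)nn2)CC1` differs from compound 3 by methyl in place of hydrogen on a saturated chain carbon bound to an amide-type nitrogen and a saturated chain carbon, the same change at the same place as from compound 1 to compound 2. If that change carries over, the step is expected to be an at least 8.5-fold lower number from compound 3 to compound 4 (0.93 log units; beyond the scatter), resting on compound 2 with 7130 nM. Compound 4 is therefore expected near 15000 nM, between 4000 nM and 130000 nM.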

Compound 4, half-maximal inhibitory concentration: > 128000 nM
Compound 4 was reported as a limit; the forecaster's own chance of this, stated with the estimate: 30%; middle value at least 8.5-fold (0.93 log units) from the limit.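

In this assay compound 4 gives > 128000 nM, which is a limit and not a number. Ethyl to isopropyl therefore does not bring the 4-chlorophenyl compound to a measurable value as it does the 2-fluorophenyl one, and with isopropylcarbamoyl in both, the swap of aromatic group gives an at least 17-fold higher number from compound 2 to compound 4 (1.25 log units; beyond the scatter). Steps joining two limits cannot be read, so whether the change does anything at all on the 4-chlorophenyl core stays unknown because both compounds sit at the same limit: the limit of > 128000 nM in this assay, at which 3 of the 4 values shown sit.

The compounds shown leave open whether tert-butylcarbamoyl or cyclohexylcarbamoyl in place of isopropylcarbamoyl would give lower numbers. They also leave open how a 2-chlorophenyl or a plain phenyl group would behave.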